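The compounds below may be only part of what the source reports. "The series", "measured", "known", "first", "only" and "open" are said of these compounds alone.

Compound 1 `COc1ccccc1Oc1ccc2c(NCCCNCc3ccco3)ccnc2c1` is measured in an ADME assay for permeability, using PAMPA, with a stated time of 30 min, at pH 7.4 (on this read-out higher numbers stand for higher permeability and lower numbers for lower permeability), where compound 1 gives 317 10^-6 cm/s. Compound 2 `c1ccc(-c2ccc3c(NCCCNCc4ccco4)ccnc3c2)cc1` gives 237 10^-6 cm/s, and compound 3 `Fc1ccc(Cc2ccc3c(NCCCNCc4ccco4)ccnc3c2)c(Cl)c1` gives 23 10^-6 cm/s. Compound 1 and compound 2 thus sit within the scatter of each other, a 1.3-fold lower number from compound 1 to compound 2 (0.13 log units; within the scatter), whereas compound 3 lies far below both, a 14-fold lower number from compound 1 to compound 3 (1.14 log units; beyond the scatter) and a 10-fold lower number from compound 2 to compound 3 (1.01 log units; beyond the scatter). Compound 4 `CC(C)(C)c1ccc(Oc2ccc3c(NCCCNCc4ccco4)ccnc3c2)cc1` has not yet been measured. It differs from compound 1 in a single place: 4-(tert-butyl)phenyl in place of 2-methoxyphenyl on an oxygen on an aromatic ring. The change keeps the attachment on an oxygen on an aromatic ring and exchanges only the aryl group carried there. Going by the values given here, the step that bears most on it is the one from compound 1 to compound 2, in which one aryl group replaced another on the core and the number stayed within the scatter; the large drops to compound 3 came with a 2-chloro-4-fluorobenzyl group, which compound 4 does not carry. A step of about a 1.3-fold lower number from compound 1 to compound 4 (0.10 log units; within the scatter) is therefore expected for compound 4, within the scatter. Compound 4 is estimated to give 250 10^-6 cm/s, with a range of 120 10^-6 cm/s to 450 10^-6 cm/s.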

Compound 4, apparent permeability: 317 10^-6 cm/s
Compound 4: the middle estimate sits 1.3-fold (0.10 log units) below what was measured; the range from low to high includes it.
By their numbers in this assay, from the lowest: compound 3; then compounds 2, 1 and 4 (each within the scatter of the next).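

In this assay, the step on the oxygen on an aromatic ring is no change at the digits printed from compound 1 to compound 4 (within the scatter), the first step shown in which that oxygen stays in place and only the aryl group on it is exchanged. Here 2-methoxyphenyl, with 8 heavy atoms and 1 hydrogen-bond acceptor, gives way to 4-(tert-butyl)phenyl, with 10 heavy atoms and 0 hydrogen-bond acceptors, so at this place these two aryl groups cannot be told apart on this read-out. No measurement is available to explain this result.

The compounds shown leave open whether an aryl group carrying an amine or a carboxylic acid on this same oxygen would stay within the scatter of compound 1. They also leave open how a benzyl group on this oxygen would read.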